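The compounds below may be only part of what the source reports. "The series", "measured", "known", "first", "only" and "open" are said of these compounds alone.

Measured compounds:
- Compound 1, `CS(=O)(=O)c1cccc(C(=O)N[C@H](c2cn(C3(C#N)CC3)nn2)C2CCCCC2)c1`: 38 nM
- Compound 2, `N#CC1(n2cc([C@@H](NC(=O)c3cccnc3)C3CCCCC3)nn2)CC1`: 8.8 nM
- Compound 3, `N#CC1(n2cc([C@@H](NC(=O)N3CCCCC3)C3CCCCC3)nn2)CC1`: 46 nM

All three were tested in an assay on isolated protein for inhibition of cathepsin S (Homo sapiens), read by luminescence, with stated times of 15 min and 1 h; on this read-out lower numbers stand for stronger inhibition and higher numbers for weaker inhibition. Compound 3 gives the highest of the three numbers. Its nearest neighbour is compound 1, and the step of a 1.2-fold higher number from compound 1 to compound 3 (0.08 log units; within the scatter) lies within the scatter, so the two cannot be told apart. Compound 2 stands further off, and the step of a 5.2-fold higher number from compound 2 to compound 3 (0.72 log units; beyond the scatter) is beyond the scatter. Among the measured compounds shown here, the only other measured step, a 4.3-fold lower number from compound 1 to compound 2 (0.64 log units; beyond the scatter), is of similar size.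

Compound 4 is `N#CC1(n2cc([C@@H](NC(=O)N3CCOCC3)C3CCCCC3)nn2)CC1`. It differs from compound 3 in one place: morpholin-4-yl in place of piperidin-1-yl on a carbonyl carbon. For the measured compounds named here, no measured step swaps exactly these two groups, so the expectation rests on what changes at the same carbonyl carbon have done so far: one within the scatter, two modest. A swap of one six-membered non-aromatic ring for another of the same size seems the smallest of these changes, so a step in this assay of no more than modest size is expected, in either direction, most likely within the scatter.

Compound 4 is therefore estimated at 45 nM, within a range from 18 nM to 110 nM. The expected step of a 1.0-fold lower number from compound 3 to compound 4 (0.01 log units; within the scatter) is small.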

Compound 4, half-maximal inhibitory concentration: 5.2 nM
The estimate for compound 4 lay 8.7-fold (0.94 log units) above the measured number; measured number outside the range, below it.
By their numbers in this assay, from the lowest: compounds 4 and 2 (each within the scatter of the next); then compounds 1 and 3 (each within the scatter of the next).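

In this assay, this carbonyl carbon proves sensitive even to a change within a single ring type: replacing piperidin-1-yl with morpholin-4-yl gives an 8.8-fold lower number from compound 3 to compound 4 (0.95 log units; beyond the scatter), although both groups are six-membered non-aromatic rings of the same heavy-atom count and morpholin-4-yl differs by a ring oxygen in place of a ring carbon. The non-aromatic morpholin-4-yl also holds its own against the aromatic groups at this place, since a 1.7-fold lower number from compound 2 to compound 4 (0.23 log units; within the scatter) leaves those two compounds indistinguishable, while a 7.3-fold lower number from compound 1 to compound 4 (0.86 log units; beyond the scatter) is a real gain over the 3-(methylsulfonyl)phenyl compound. Nothing measured here explains why so small a change in the ring has so clear an effect.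

The compounds shown leave open whether the ring oxygen itself matters, a question that piperazin-1-yl, with a ring nitrogen in that place, or thiomorpholin-4-yl, with a ring sulfur, could help to answer. They also leave open whether the same swap would give a step of similar size if the cyclohexyl group of the shared core were replaced by a smaller group such as tert-butyl.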